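The source may hold more compounds than are shown below. What is called first, only, known or untested is meant among the compounds shown, and "the series" means these compounds.

Of the compounds shown here, two built on one shared core have so far been tested in an assay on a protein complex for positive allosteric modulation of Neuronal acetylcholine receptor; alpha4/beta2 (Homo sapiens); on this read-out higher numbers stand for larger maximal responses and lower numbers for smaller maximal responses. Compound 1 `Fc1ccc(-c2cc(-c3cnn(C4CCNCC4)c3)on2)c(Cl)c1` reaches 56%. Compound 2 `Clc1cnccc1-c1cc(-c2cnn(C3CCNCC3)c2)on1` reaches 50%, the lower of the two numbers, though its gap to compound 1 lies within the scatter of repeated measurements. The step between them, a number 6 percentage points lower from compound 1 to compound 2 (within the scatter), came from putting 3-chloropyridin-4-yl in place of 2-chloro-4-fluorophenyl on an aromatic carbon of the core, and it left the maximal response essentially where it was.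

Compound 3 `Clc1cccc(Cl)c1-c1cc(-c2cnn(C3CCNCC3)c2)on1` has not yet been measured. It differs from compound 2 in one place: 2,6-dichlorophenyl in place of 3-chloropyridin-4-yl on an aromatic carbon. Among the measured compounds shown here, only one measured step touches this part of the core, the one from compound 1 to compound 2, which exchanged one aromatic ring for another at an aromatic carbon and stayed within the scatter. On the two numbers available, such an exchange has moved the read-out little, and nothing else informs the swap of a six-membered aromatic ring with one hetero atom for a six-membered aromatic ring of carbon only. For compound 3 no change beyond the scatter is therefore expected, that is a number 3 percentage points higher from compound 2 to compound 3 (within the scatter) in this assay. Compound 3 is expected to reach about 53%, between 40% and 66%.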

Compound 3, largest response reached (reported as efficacy), in percent of the reference or control that the assay uses: 73%
For compound 3 the middle estimate is 20 percentage points below the measured one, and the stated range ends below it.
By their numbers in this assay, from the lowest: compounds 2 and 1 (each within the scatter of the next); then compound 3.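

The aromatic carbon next to the ring nitrogen is more sensitive than the first exchange suggested: in this assay the read-out shows a number 23 percentage points higher from compound 2 to compound 3 (beyond the scatter), and also a number 17 percentage points higher from compound 1 to compound 3 (beyond the scatter). So exchanging one aromatic ring for another here can change the maximal response, and of these three groups, 2,6-dichlorophenyl gives a result that stands apart from the other two. The step from 3-chloropyridin-4-yl changes two things at once, removing the ring nitrogen and adding a second chlorine, and no information is available to explain the rise in the read-out.

The compounds shown leave open which of those two changes matters, and whether the two chlorines of 2,6-dichlorophenyl are needed at all; plain phenyl, 2-chlorophenyl and 3,5-dichloropyridin-4-yl would help separate these possibilities. From the compounds shown here alone, it is also open whether other groups in the same two places on the ring, such as the methyl groups of 2,6-dimethylphenyl or the fluorines of 2,6-difluorophenyl, would give a similar maximal response.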